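This account rests on a few compounds, and the source may have more. Where it says the series, first, only, none or still open, it means among the compounds named here.

Measured so far in an ADME assay on NIH3T3 cells (Mus musculus) for cytotoxicity, read by MTT assay, with a stated time of 24 h; on this read-out lower numbers stand for stronger inhibition and higher numbers for weaker inhibition:
compound 1 `O=C(CSc1nnc(-c2ccncc2)o1)N/N=C/c1ccc([N+](=O)[O-])cc1` — 195000 nM
compound 2 `Cc1ccc(/C=N/NC(=O)CSc2nnc(-c3ccncc3)o2)cc1` — 185000 nM

Compound 1 stands highest of the two numbers in this assay; the nearest is compound 2, reached by a 1.1-fold lower number from compound 1 to compound 2 (0.02 log units; within the scatter). Compound 3 `O=C(CSc1nnc(-c2ccncc2)o1)N/N=C/c1ccc(O)c(O)c1` differs from compound 1 by 3,4-dihydroxyphenyl in place of 4-nitrophenyl on a carbon with a double bond to nitrogen. For the measured compounds named here, the single measured step, a 1.1-fold lower number from compound 1 to compound 2 (0.02 log units; within the scatter), also exchanges the substituent of the phenyl ring attached to the imine carbon, methyl in place of nitro, and it produced no movement beyond the scatter. The change to 3,4-dihydroxyphenyl adds two hydrogen-bond donors where that step added none, so it bears on the present change only loosely; nothing measured points to a direction. The expectation is therefore no step beyond the scatter in this assay. Compound 3 is expected at about 190000 nM, with a range from 80000 nM to 400000 nM. The step this estimate implies, a 1.0-fold lower number from compound 1 to compound 3 (0.01 log units; within the scatter), is expected to stay within the scatter.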

Compound 3, half-maximal inhibitory concentration: 154000 nM
The estimate for compound 3 lay 1.2-fold (0.09 log units) above the measured number; measured number inside the range.
By their numbers in this assay, from the lowest: compounds 3, 2 and 1 (each within the scatter of the next).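

In this assay, 3,4-dihydroxyphenyl on a carbon with a double bond to nitrogen gives a 1.3-fold lower number from compound 1 to compound 3 (0.10 log units; within the scatter) and a 1.2-fold lower number from compound 2 to compound 3 (0.08 log units; within the scatter), so a third group at this position also stays inside the scatter. This group brings 2 hydrogen-bond donors where 4-nitrophenyl has 0, and that difference does not separate compound 3 from compound 1 on this read-out. Nothing available explains why the three compounds sit so close together.

Open, going by these compounds, is whether an amine or a carboxylic acid on the phenyl ring, or a cyclohexyl group in place of that ring, would move the number beyond the scatter in this assay at this position. Equally open, on these data alone, is whether any change in the shared core, away from this position, would do so.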